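The source may hold more compounds than are shown below. What is called first, only, known or untested is meant among the compounds shown, and "the series" means these compounds.

In a functional assay on A549 cells (Homo sapiens) for inhibition, read by MTT assay, with a stated time of 72 h, tested at 20 uM (a higher number here means more inhibition at the concentration tested (going by the name of the read-out), a lower number less inhibition), compound 1, `CN(c1ccc(Oc2ncnc3ccsc23)cc1)c1nccc(N2CCc3ccccc3C2)n1`, gives 69.9%. Compound 2, `CN(c1ccc(Oc2ncnc3ccsc23)cc1)c1nccc(N2CCc3ccccc32)n1`, carries 2,3-dihydro-1H-indol-1-yl in place of 1,2,3,4-tetrahydroisoquinolin-2-yl on an aromatic carbon, and in this assay compound 2 gives 58.2%, so that a number 11.7 percentage points lower from compound 1 to compound 2 (beyond the scatter). Compound 3, `c1ccc2c(c1)CCN(c1ccnc(Nc3ccc(Oc4ncnc5sccc45)cc3)n1)C2`, shares much with compound 1, but the difference between the two cores is not broken down here; in this assay compound 3 gives 34%, the lowest of the three values, and its gap to compound 2 and to compound 1 lies beyond the scatter in both cases. Compound 4, `c1ccc2c(c1)CCN2c1ccnc(Nc2ccc(Oc3ncnc4sccc34)cc2)n1`, has not been measured; it carries 2,3-dihydro-1H-indol-1-yl in place of 1,2,3,4-tetrahydroisoquinolin-2-yl on an aromatic carbon, the same change that was made from compound 1 to compound 2 and that occurs twice among these compounds. For the measured compounds named here, because a number 11.7 percentage points lower from compound 1 to compound 2 (beyond the scatter), a step of similar size is expected from compound 3 to compound 4, namely a number 10 percentage points lower from compound 3 to compound 4 (within the scatter), though with only one earlier example and a core that differs, the step is uncertain. Compound 4 is therefore estimated at 24% in this assay, with a range from 8% to 40%.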

Compound 4, a percentage reported as inhibition, at one concentration (the size of the read-out at that concentration, not a potency): 2.81%
Compound 4: middle estimate off by 21.2 percentage points, on the high side; measured number below the stated range.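

In this assay the same replacement of 1,2,3,4-tetrahydroisoquinolin-2-yl by 2,3-dihydro-1H-indol-1-yl again goes with less inhibition, the new step being a number 31.2 percentage points lower from compound 3 to compound 4 (beyond the scatter). The direction of the change therefore carries over between the two cores, but its size does not: the same change on two cores in this assay, a number 11.7 percentage points lower (beyond the scatter) from compound 1 to compound 2 and a number 31.2 percentage points lower (beyond the scatter) from compound 3 to compound 4, 19.5 percentage points apart, beyond the scatter of two such steps The step measured on one core was thus no guide to its size on the other, and these two pairs neither show what in the cores sets that size nor establish a rule for any further core.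

The compounds shown leave open whether the same direction would hold for other groups on this aromatic carbon, such as a morpholine, a piperidine or an open-chain dimethylamine. They also do not break the difference between the two cores down into its parts, and they leave open which of those parts goes with the different size of the step.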